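A few compounds are considered here, and "the series" means these few. Any claim that something is new, unique, unknown or untested is made for them only; others in the source may bear on it.

Compound 1 `CCOC(=O)c1cnc(N2CCN(Cc3cccc(C#N)c3)CC2)nc1Oc1c(C)cc(-c2ccc(C#N)cc2)cc1C` gives only a limit of > 125000 nM in an ADME assay on MT4 cells (Homo sapiens) for cytotoxicity, read by MTT assay, with a stated time of 4 days; a lower number here means that less compound is tolerated, a higher number that more compound is tolerated.
Compound 2 `CCOC(=O)c1cnc(N2CCN(Cc3ccc(Br)cc3)CC2)nc1Oc1c(C)cc(-c2ccc(C#N)cc2)cc1C` likewise gives only a limit of > 125000 nM in this assay.
Compound 3 `CCOC(=O)c1cnc(N2CCN(Cc3ccc(C(N)=O)cc3)CC2)nc1Oc1c(C)cc(-c2ccc(C#N)cc2)cc1C` gives 66500 nM in this assay.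

Among the measured compounds shown here, compound 3 therefore stands as the only numbered value among the three, the other two being limits (the limit of > 125000 nM in this assay, at which 2 of the 3 values shown sit). Compound 4 `CCOC(=O)c1cnc(N2CCN(Cc3ccc(S(N)(=O)=O)cc3)CC2)nc1Oc1c(C)cc(-c2ccc(C#N)cc2)cc1C` differs from compound 3 by sulfamoyl in place of carbamoyl on an aromatic carbon. The measured steps that bear on this change are those that arrive at the carbamoyl group: an at least 1.8-fold lower number from compound 1 to compound 3 (0.27 log units; that floor lies within the scatter) and an at least 1.8-fold lower number from compound 2 to compound 3 (0.27 log units; that floor lies within the scatter), each of them a floor that lies within the scatter. Nothing measured here separates sulfamoyl from carbamoyl, so the step of a 1.2-fold higher number from compound 3 to compound 4 (0.08 log units; within the scatter) is expected to stay within the scatter. Compound 4 is accordingly expected to give 80000 nM in this assay, between 30000 nM and 125000 nM.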

Compound 4, half-maximal cytotoxic concentration: >= 7930 nM
Compound 4 gave a limit, no number; the forecaster's own chance of this, stated with the estimate: 40%; the middle value is on the limit's open side.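

In this assay compound 4 gives only a limit of >= 7930 nM and no number, so its steps from compound 1, compound 2 and compound 3 cannot be read. As far as these compounds go, whether sulfamoyl and carbamoyl differ in this read-out remains open.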